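The source may report more compounds than this note shows. Statements on the series, on what has been measured and on what is new or still open speak of the compounds shown alone.

Measured so far in an assay on HEK293 cells for inhibition of protein deacetylase HDAC6 (Homo sapiens); a lower number here means a stronger inhibitor, a higher number a weaker inhibitor:
- compound 1, `CCSC(=S)SCC(=O)c1cccc(S(=O)(=O)Nc2cccc(C(N)=O)c2)c1`, gives 181 nM
- compound 2, `CCSC(=S)SCC(=O)c1ccc(C(=O)N[C@@H](C)c2ccccc2)s1`, gives 135 nM
- compound 3, `CCSC(=S)SCC(=O)c1ccc(C)cc1`, gives 1250 nM

All three share the same core; they differ only in what hangs from the aromatic ring that carries the ketone. Compound 3 has the highest number of the three. The gap to compound 1, the nearest, and the gap to compound 2, the furthest, both lie beyond the usual scatter, so compound 3 is the weakest inhibitor in this set. Compounds 1 and 2 both carry a larger group with an amide or sulfonamide and both give lower numbers than compound 3, which bears only a methyl.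

Compound 4, `CCSC(=S)SCC(=O)c1ccc(NS(C)(=O)=O)cc1`, has not yet been measured. It differs from compound 3 in one place: methanesulfonamido in place of methyl on an aromatic carbon. Given that the two compounds with a larger, more elaborate group give lower numbers than compound 3, a moderate decrease in number is expected in this assay for compound 4, possibly beyond the scatter, though no measured pair isolates this exact change. The expected step from compound 3 is a 2.5-fold lower number from compound 3 to compound 4 (0.40 log units; beyond the scatter). Compound 4 is therefore estimated at 500 nM, with a range from 150 nM to 1500 nM.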

Compound 4, half-maximal inhibitory concentration: 1090 nM
The estimate for compound 4 lay 2.2-fold (0.34 log units) below the measured number; low and high end bracket the measured number.
By their numbers in this assay, from the lowest: compounds 2 and 1 (each within the scatter of the next); then compounds 4 and 3 (each within the scatter of the next).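

In this assay, methanesulfonamido in place of methyl on this aromatic carbon gives a 1.1-fold lower number from compound 3 to compound 4 (0.06 log units; within the scatter). Among these compounds, this is the first pair here that differs in one place, and it shows that the number stays within the scatter when a single carbon gives way to a group of five heavy atoms carrying a hydrogen-bond donor and acceptors, so at this position a larger group of this kind is not enough to give a stronger inhibitor. Nothing measured here explains why the number stays where it is.

On these data alone, whether an amine or a carboxylic acid on this same carbon would shift the number remains open. So does whether a longer chain in place of the methyl of the methanesulfonamido group would do so.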